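The source may report more compounds than this note shows. Statements on the series, on what has been measured and on what is new or still open speak of the compounds shown alone.

Three compounds have so far been measured in an assay on Sf9 cells for inhibition of serine/threonine-protein kinase 4 (Homo sapiens), read by luminescence and ADP-Glo, with a stated time of 1 h, in the presence of a further agent that is not named here; a higher number here means a weaker inhibitor, a lower number a stronger inhibitor:

compound 1, `CC(C)C1C(=O)N(C)c2cnc(Nc3ccc(S(N)(=O)=O)cc3)nc2N1C`, 254 nM
compound 2, `CN1C(=O)C(CC2CC2)N(C)c2nc(Nc3ccc(S(N)(=O)=O)cc3)ncc21`, 211 nM
compound 3, `CC(C)CC1C(=O)N(C)c2cnc(Nc3ccc(S(N)(=O)=O)cc3)nc2N1C`, 77 nM

Compound 3 gives the lowest number of the three. Its separation from the others is beyond the scatter in both directions: a 3.3-fold lower number from compound 1 to compound 3 (0.52 log units; beyond the scatter) and a 2.7-fold lower number from compound 2 to compound 3 (0.44 log units; beyond the scatter). The remaining pair lies within the scatter, a 1.2-fold lower number from compound 1 to compound 2 (0.08 log units; within the scatter), so compound 1 and compound 2 cannot be ordered against each other.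

Compound 4, `CN1C(=O)C(c2ccccc2)N(C)c2nc(Nc3ccc(S(N)(=O)=O)cc3)ncc21`, differs from compound 3 in one place: phenyl in place of isobutyl on a saturated ring carbon. All three measured steps change the substituent on this same saturated ring carbon, and none of them moves the number by more than a modest amount. They therefore bear on the present change only in showing that the group at this position shifts the result modestly; none of them brings in an aromatic ring there, so the direction of the step is not settled by the data. Her expectation is that compound 4 lands close to compound 3, with a somewhat weaker result more likely than a stronger one, giving an estimate of 120 nM for compound 4, with a range from 30 nM to 500 nM. The step this estimate implies is a 1.6-fold higher number from compound 3 to compound 4 (0.19 log units; within the scatter), which is expected to stay within the modest sizes seen so far.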

Compound 4, half-maximal inhibitory concentration: 383 nM
Compound 4: the middle estimate sits 3.2-fold (0.50 log units) below what was measured, within the range that was stated.
By their numbers in this assay, from the lowest: compound 3; then compounds 2, 1 and 4 (each within the scatter of the next).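

In this assay, compound 4 brings the first aromatic ring to this saturated ring carbon, and phenyl does not match isobutyl there: a 5.0-fold higher number from compound 3 to compound 4 (0.70 log units; beyond the scatter). Phenyl cannot be separated from the two other groups, with a 1.8-fold higher number from compound 2 to compound 4 (0.26 log units; within the scatter) and a 1.5-fold higher number from compound 1 to compound 4 (0.18 log units; within the scatter), so isopropyl, cyclopropylmethyl and phenyl form one group within the scatter of their neighbours, and compound 3 alone stands clearly apart as the strongest of the four. The position therefore accepts both a six-membered aromatic ring and small saturated groups at a similar level, with the isobutyl compound the only one to give a clearly lower number, and no accompanying measurement accounts for this.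

As far as these compounds go, what remains open is whether a benzyl group, which keeps the phenyl ring but sets it on a chain carbon as in isobutyl and cyclopropylmethyl, would behave like compound 3 or like compound 4. From the compounds shown here alone, it is equally open whether a longer chain such as n-pentyl, or a chain ending in an amine or a carboxylic acid, would lower the number further or raise it.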